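The source may report more compounds than this note shows. Statements on the series, on what has been measured and on what is new or still open speak of the compounds shown alone.

Three compounds built on one shared core were tested in a functional assay on MCF7 cells (Homo sapiens) for inhibition, read by MTT assay, with a stated time of 24 h; on this read-out higher numbers stand for weaker inhibition and lower numbers for stronger inhibition. Compound 1 `CCOC(=O)C1=Cc2ccccc2OC1(OCc1cn(-c2ccc(F)cc2)nn1)C(F)(F)F` gives 9100 nM, compound 2 `CCOC(=O)C1=Cc2ccccc2OC1(OCc1cn(CC(=O)NC2CCCCC2)nn1)C(F)(F)F` gives 12100 nM, and compound 3 `CCOC(=O)C1=Cc2ccccc2OC1(OCc1cn(CC(=O)Nc2ccc(I)cc2Cl)nn1)C(F)(F)F` gives 28100 nM, the highest of the three, set apart by the modest steps of a 3.1-fold higher number from compound 1 to compound 3 (0.49 log units; beyond the scatter) and a 2.3-fold higher number from compound 2 to compound 3 (0.37 log units; beyond the scatter). Compound 4 `CCOC(=O)C1=Cc2ccccc2OC1(OCc1cn(-c2ccc([N+](=O)[O-])cc2)nn1)C(F)(F)F` differs from compound 3 by 4-nitrophenyl in place of ((2-chloro-4-iodophenyl)carbamoyl)methyl on an aromatic nitrogen. The step that bears on this is a 3.1-fold higher number from compound 1 to compound 3 (0.49 log units; beyond the scatter), because compound 1, which also carries an aryl group directly on that aromatic nitrogen, gives 9100 nM; compound 4 essentially undoes that change. Compound 4 is therefore expected to give about 10000 nM, within a range of 4500 nM to 22000 nM. The expected step is a 2.8-fold lower number from compound 3 to compound 4 (0.45 log units; beyond the scatter), a modest lowering.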

Compound 4, half-maximal inhibitory concentration: > 150000 nM
Compound 4: no number, only a limit; the forecaster's own chance of this, stated with the estimate: 5%; middle value at least 15-fold (1.17 log units) from the limit.
By their numbers in this assay, from the lowest: compounds 1 and 2 (each within the scatter of the next); then compound 3. At a limit, above all of these: compound 4.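

In this assay, compound 4 gives no number, only a limit: the limit of > 150000 nM in this assay, at which 1 of the 4 values shown sits. Within the data shown here, exchanging only fluoro for nitro on an aromatic carbon of the aryl group gives an at least 16-fold higher number from compound 1 to compound 4 (1.21 log units; beyond the scatter), so a single substituent on that aryl group shifts the read-out by more than any step among the earlier compounds. Against the two amide-bearing groups, the steps are an at least 12-fold higher number from compound 2 to compound 4 (1.09 log units; beyond the scatter) and an at least 5.3-fold higher number from compound 3 to compound 4 (0.72 log units; beyond the scatter), so an aryl group directly on the aromatic nitrogen does not by itself keep the number low.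

The compounds shown leave open how far the read-out of compound 4 lies past its limit. They also leave open whether an amine or a nitrile in place of nitro would behave like fluoro or like nitro.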